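A ring-nitrogen shift within a series sitting at the limit

This account rests on a few compounds, and the source may have more. Where it says the series, first, only, none or still open, it means among the compounds named here.

Compound 3 `C[C@H](NC(=O)c1cc(C(F)(F)F)nn1C)c1nc(-c2ccccn2)no1` was tested in an assay on T-REx-293 cells for inhibition of potassium channel subfamily T member 1 (Homo sapiens), read by patch clamp (a higher number here means a weaker inhibitor, a lower number a stronger inhibitor), and gave only a limit, > 30000 nM. Its two neighbours stand no differently. Compound 1 `Cc1cccc(-c2nnc([C@H](C)NC(=O)c3cc(C4CC4)nn3C)o2)c1` also reached only a limit, > 30000 nM. Compound 2 `Cc1cccc(-c2noc([C@H](C)NC(=O)c3cc(C(F)(F)F)nn3C)n2)n1` likewise gave a limit, > 30000 nM. The single step measured among these three, a step that the two limits leave unreadable from compound 2 to compound 3, therefore cannot be sized, and the limit of > 30000 nM in this assay, at which 3 of the 3 values shown sit, shows every value sitting together. Compound 4 `C[C@H](NC(=O)c1cc(C(F)(F)F)nn1C)c1nc(-c2cccnc2)no1` differs from compound 3 by pyridin-3-yl in place of pyridin-2-yl on an aromatic carbon. Among the measured compounds shown here, no measured step speaks to this change, and nothing here separates the compounds, so compound 4 is expected to remain at the limit as well. The expected step that the limit leaves unreadable from compound 3 to compound 4 is accordingly nothing beyond the scatter. Compound 4 is therefore estimated at 40000 nM, within 15000 nM to 100000 nM.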

Compound 4, half-maximal inhibitory concentration: 11800 nM
The estimate for compound 4 lay 3.4-fold (0.53 log units) above the measured number; measured number outside the range, below it.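

Swapping pyridin-2-yl for pyridin-3-yl on this aromatic carbon, between two ring nitrogen atoms, gives the only readable number in this assay, with an at least 2.5-fold lower number from compound 3 to compound 4 (0.40 log units; beyond the scatter). The placing of the pyridine nitrogen therefore matters here, and pyridin-3-yl also stands apart from 6-methylpyridin-2-yl, with an at least 2.5-fold lower number from compound 2 to compound 4 (0.40 log units; beyond the scatter). Only compound 4 has left the limit: the limit of > 30000 nM in this assay, at which 3 of the 4 values shown sit.

On these data alone, the full size of both steps stays open, and the remaining step, between the two compounds at the limit, cannot be read. As far as these compounds go, whether pyridin-4-yl, or an amine on pyridin-3-yl, would lower the number further also stays open.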